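Chloro for methoxy on the anilide of a thione core

The source may report more compounds than this note shows. Statements on the series, on what has been measured and on what is new or still open speak of the compounds shown alone.

Measured so far in a functional assay on MCF7 cells (Homo sapiens) for inhibition, read by sulforhodamine B assay, with a stated time of 24 h; a lower number here means a stronger inhibitor of growth, a higher number a weaker inhibitor of growth:
- compound 1, `CCOC(=O)C1=C(C)NC(=S)NC1c1cn(-c2ccccc2)nc1-c1ccccc1`: 42000 nM
- compound 2, `COc1ccc(NC(=O)C2=C(C)NC(=S)NC2c2cn(-c3ccccc3)nc2-c2ccccc2)cc1`: 77300 nM

Within the data shown here, compound 2 and compound 1 sit within the scatter of each other, as the single measured step shows: a 1.8-fold higher number from compound 1 to compound 2 (0.26 log units; within the scatter). That step changed the group on the carbonyl carbon, so it says nothing about substituents on the outer aromatic ring. Compound 3, `CC1=C(C(=O)Nc2ccc(Cl)cc2)C(c2cn(-c3ccccc3)nc2-c2ccccc2)NC(=S)N1`, differs from compound 2 by chloro in place of methoxy on an aromatic carbon. Among the measured compounds shown here, with no measured step touching that ring, no change beyond the scatter is expected in this assay: a 1.1-fold lower number from compound 2 to compound 3 (0.04 log units; within the scatter). Compound 3 is therefore estimated at 70000 nM, between 30000 nM and 160000 nM.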

Compound 3, concentration for 50% growth inhibition: 34700 nM
Beside the measured number, compound 3's estimate is 2.0-fold (0.30 log units) above it; low and high end bracket the measured number.
By their numbers in this assay, from the lowest: compounds 3, 1 and 2 (each within the scatter of the next, the first and the last beyond it).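

In this assay the substituent on the outer aromatic ring can shift the number: chloro in place of methoxy gives a 2.2-fold lower number from compound 2 to compound 3 (0.35 log units; beyond the scatter), a modest step just beyond the scatter. Replacing ethoxy on the carbonyl carbon with (4-chlorophenyl)amino gives a 1.2-fold lower number from compound 1 to compound 3 (0.08 log units; within the scatter), which is within the scatter, so that swap alone leaves no readable difference. Nothing available explains the chloro result. Still open, going by these compounds, is whether a nitrile, a nitro group or a carboxylic acid at this place would move the number further than chloro does.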